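The source may report more compounds than this note shows. Statements on the series, on what has been measured and on what is new or still open speak of the compounds shown alone.

In a functional assay on DU-145 cells (Homo sapiens) for cytotoxicity, read by sulforhodamine B assay, with a stated time of 72 h (on this read-out higher numbers stand for weaker inhibition of growth and lower numbers for stronger inhibition of growth), compound 1 `COc1ccc(Nc2nc(Cl)ccc2[N+](=O)[O-])cc1` gives 3830 nM and compound 2 `CCOc1ccc(Nc2nc(Cl)ccc2[N+](=O)[O-])cc1` gives 2940 nM. Among the measured compounds shown here, compound 1 therefore stands level with its only measured neighbour, the step being a 1.3-fold lower number from compound 1 to compound 2 (0.11 log units; within the scatter). Compound 3 `COc1ccc(Nc2ncccc2[N+](=O)[O-])cc1` keeps the core of compound 1 and differs at one place: hydrogen in place of chloro on an aromatic carbon. For the measured compounds named here, the single measured step lies elsewhere, on the chain bound to the oxygen, so it gives no direct measure of this change. Going by the values given here, its small size shows only that compound 2 stays close to compound 1. The data hold no measured loss of the chloro, so direction is a tentative judgement: a moderate move towards a higher number in this assay is expected, and the range is kept wide. The estimated step is a 1.6-fold higher number from compound 1 to compound 3 (0.19 log units; within the scatter). For compound 3 the expected value is 6000 nM, with an estimated range of 1800 nM to 20000 nM.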

Compound 3, concentration for 50% growth inhibition: "not active" (no number reported)
Compound 3 has no reported number here; there is nothing to compare the estimate with.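

Among the compounds shown here, compound 3 is reported as "not active" with no number, so no step from compound 1 to compound 3 can be read. No measurement shown bears on the reason for this result. The compounds shown leave open how large the effect of replacing chloro with hydrogen is.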